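This account rests on a few compounds, and the source may have more. Where it says the series, first, only, none or still open, it means among the compounds named here.

Of the compounds shown here, three sharing one core have been tested in a functional assay on HL-60 cells (Homo sapiens) for antiproliferative activity, read by MTT assay, with a stated time of 24 h; on this read-out higher numbers stand for weaker inhibition and lower numbers for stronger inhibition. Compound 1 `CNC(=O)c1ccccc1Oc1nc(Nc2ccccc2OC)ncc1Br` carries a 2-methoxyphenyl on a nitrogen on an aromatic ring. In this assay compound 1 gives only a limit, > 50000 nM. Compound 2 `CNC(=O)c1ccccc1Oc1nc(Nc2cccc(C)c2)ncc1Br` carries a 3-methylphenyl at that position, and in this assay compound 2 gives 16200 nM. Compound 3 `CNC(=O)c1ccccc1Oc1nc(Nc2ccc(Cl)cc2F)ncc1Br` carries a 4-chloro-2-fluorophenyl there. In this assay compound 3 likewise gives only a limit, > 50000 nM. Compound 3 thus stands at the limit of > 50000 nM in this assay, at which 2 of the 3 values shown sit, and a number for it is not known. The step of an at least 3.0-fold lower number from compound 1 to compound 2 (0.48 log units; beyond the scatter) lies beyond the scatter, whereas an at least 3.0-fold higher number from compound 2 to compound 3 (0.48 log units; beyond the scatter) runs the other way. The step that the two limits leave unreadable from compound 1 to compound 3 cannot be read, since both ends are limits.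

Compound 4 `CNC(=O)c1ccccc1Oc1nc(Nc2cccc(C(C)C)c2)ncc1Br` is not yet measured. Its change from compound 3 is 3-isopropylphenyl in place of 4-chloro-2-fluorophenyl on a nitrogen on an aromatic ring. The measured step that bears most directly on it is an at least 3.0-fold higher number from compound 2 to compound 3 (0.48 log units; beyond the scatter), which replaced a 3-methylphenyl by the 4-chloro-2-fluorophenyl; the change to compound 4 reverses that kind of move and places a 3-isopropylphenyl there instead. The expectation is therefore a step down in number, an at least 3.3-fold lower number from compound 3 to compound 4 (0.52 log units; beyond the scatter). Compound 4 is expected to give about 15000 nM in this assay, with a likely range from 5000 nM to 50000 nM.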

Compound 4, half-maximal inhibitory concentration: 17500 nM
For compound 4 the middle estimate is 1.2-fold (0.07 log units) below the measured one; the measured number falls inside the stated range.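

In this assay, isopropyl in place of methyl on an aromatic carbon gives a 1.1-fold higher number from compound 2 to compound 4 (0.03 log units; within the scatter), so the 3-methylphenyl and the 3-isopropylphenyl cannot be told apart on this read-out. For the compounds shown here, this is the first comparison between two groups that both give a number, and it shows that the measurable value of compound 2 was not unique to its methyl group. With a second group, the steps of an at least 2.8-fold lower number from compound 3 to compound 4 (0.45 log units; beyond the scatter) and an at least 2.8-fold lower number from compound 1 to compound 4 (0.45 log units; beyond the scatter) now repeat what compound 2 alone had shown against the 4-chloro-2-fluorophenyl and the 2-methoxyphenyl, while compound 1 and compound 3 remain limits and not numbers: the limit of > 50000 nM in this assay, at which 2 of the 4 values shown sit.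

The compounds shown do not separate the place of a group on the phenyl from its kind, and it stays open what a 3-methoxyphenyl or a 3-chlorophenyl would give. From the compounds shown here alone, it is equally open whether a longer chain or an amine at that place would move the number beyond the scatter of these two values.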